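This account rests on a few compounds, and the source may have more. Where it says the series, first, only, none or still open, it means among the compounds named here.

Measured so far in an assay on HEK293 cells for negative allosteric modulation of metabotropic glutamate receptor 5 (Homo sapiens), read by FLIPR; on this read-out higher numbers stand for weaker inhibition and lower numbers for stronger inhibition:
- compound 1, `O=C(c1ccc(F)c(F)c1)N1CC(c2nc(-c3cccc(F)c3)no2)C1`, reported only as a limit: > 10000 nM
- compound 2, `CC1CCN(C(=O)N2CC(c3nc(-c4cccc(Cl)c4)no3)C2)CC1`, reported only as a limit: > 10000 nM

Compound 2 stands at the limit of this assay, with no number of its own; the same holds for the other value shown, (the limit of > 10000 nM in this assay, at which 2 of the 2 values shown sit). Going by the values given here, nothing here separates compound 1 from compound 2, and no measured step exists within the pair.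

Compound 3, `O=C(N1CCCCC1)N1CC(c2nc(-c3cccc(Cl)c3)no2)C1`, carries the change (hydrogen in place of methyl on a saturated ring carbon).

Removing the methyl leaves the rest of compound 2 intact. With both measured compounds sitting at the limit, there is no basis to expect movement beyond the scatter in this assay, and the expected step is a step that the limit leaves unreadable from compound 2 to compound 3, with the most likely outcome being another limit rather than a number. Compound 3 is therefore estimated at 15000 nM, with a range from 5000 nM to 50000 nM.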

Compound 3, half-maximal inhibitory concentration: > 10000 nM
Compound 3 gave a limit, no number; the forecaster's own chance of this, stated with the estimate: 75%; the middle value does not contradict the limit.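

Compound 2 and compound 3 are both reported only as limits in this assay, so no step between them can be read: the limit of > 10000 nM in this assay, at which 3 of the 3 values shown sit.

The compounds shown leave open which structural change, if any, would give a measurable number in this assay.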